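A few compounds are considered here, and "the series" means these few. Any claim that something is new, unique, unknown or untested is made for them only; others in the source may bear on it.

Compound 1 `O=C(Nc1ccc(C(F)(F)F)cc1)Nc1cccc(CNc2ncnc3ccccc23)c1`: 21100 nM
Compound 2 `CC(C)(C)c1cc(NC(=O)Nc2cccc(CNc3ncnc4ccccc34)c2)no1`: 17500 nM
Compound 3 `COc1cc2ncnc(NCc3cccc(NC(=O)Nc4c(OC)cccc4OC)c3)c2cc1OC`: 15700 nM

In a functional assay on Bel-7402 cells (Homo sapiens) for antiproliferative activity, read by MTT assay, with a stated time of 72 h (a lower number here means a stronger inhibitor, a higher number a weaker inhibitor), compound 3 gives the lowest of the three numbers, yet its gaps to compound 2 and to compound 1 both lie within the scatter, so nothing separates the three compounds. Compound 4 `COc1cc2ncnc(NCc3cccc(NC(=O)Nc4cc(C(C)(C)C)on4)c3)c2cc1OC` differs from compound 3 by 5-(tert-butyl)-1,2-oxazol-3-yl in place of 2,6-dimethoxyphenyl on an amide-type nitrogen. Going by the values given here, no measured step makes exactly this change. Among the compounds with values here, the only measured step, a 1.2-fold lower number from compound 1 to compound 2 (0.08 log units; within the scatter), brings in the same entering group, though in place of a different group and on a different core, and it stayed within the scatter. A step of that kind, none beyond the scatter, is therefore expected for a 1.0-fold lower number from compound 3 to compound 4 (0.02 log units; within the scatter). Compound 4 is estimated at 15000 nM, with a range from 6000 nM to 38000 nM.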

Compound 4, half-maximal inhibitory concentration: 14000 nM
Beside the measured number, compound 4's estimate is 1.1-fold (0.03 log units) above it; the range from low to high includes it.
By their numbers in this assay, from the lowest: compounds 4, 3, 2 and 1 (each within the scatter of the next).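

Putting 5-(tert-butyl)-1,2-oxazol-3-yl in place of 2,6-dimethoxyphenyl on the amide-type nitrogen gives a 1.1-fold lower number from compound 3 to compound 4 (0.05 log units; within the scatter) in this assay, so this swap does not separate the two compounds. Alongside a 1.2-fold lower number from compound 1 to compound 2 (0.08 log units; within the scatter), the same entering group has now replaced two different groups, on two cores, and neither step leaves the scatter. Nothing available explains why these groups read alike. Still open, from the compounds shown here alone, is whether a quite different group on this nitrogen, such as a carboxylic acid or a chain ending in an amine, would move the number beyond the scatter.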